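This account rests on a few compounds, and the source may have more. Where it says the series, first, only, none or still open, it means among the compounds named here.

Working notes on the hydroxamic acid series.

Compound 2 `O=C(/C=C/c1ccc(/C=C/C(=O)c2ccccc2)cc1)NO` gives 3000 nM in a physicochemical assay for solubility, at pH 7.4; a higher number here means a more soluble compound, a lower number a less soluble compound. Compound 1 `CN1CCN(c2ccc(C(=O)/C=C/c3ccc(/C=C/C(=O)NO)cc3)cc2)CC1` carries 4-methylpiperazin-1-yl in place of hydrogen on an aromatic carbon and gives 1000 nM in this assay; the step is a 3.0-fold lower number from compound 2 to compound 1 (0.48 log units; beyond the scatter). Compound 3 `O=C(/C=C/c1ccc(/C=C/C(=O)c2ccccc2)cn1)NO` gives 27000 nM in this assay, the highest number among the three measured compounds. The difference between the core of compound 3 and the core of compound 2 is not broken down here; the two values alone show compound 3 above compound 2.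

Compound 4 `CN1CCN(c2ccc(C(=O)/C=C/c3ccc(/C=C/C(=O)NO)nc3)cc2)CC1` has not yet been measured in this assay. It differs from compound 3 by 4-methylpiperazin-1-yl in place of hydrogen on an aromatic carbon, which is the same change as that from compound 2 to compound 1, made on the core of compound 3 instead. Within the data shown here, only one measured instance of this change is available, so the expectation rests on that single step. For compound 4 a step of a 3.0-fold lower number from compound 3 to compound 4 (0.48 log units; beyond the scatter) is expected, since the same change gave a 3.0-fold lower number from compound 2 to compound 1 (0.48 log units; beyond the scatter). The value expected for compound 4 in this assay is therefore 9000 nM, with a plausible range from 4500 nM to 18000 nM.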

Compound 4, solubility: 29000 nM
The estimate for compound 4 lay 3.2-fold (0.51 log units) below the measured number; the measured number lies above the stated range.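

In this assay, placing 4-methylpiperazin-1-yl on the aromatic carbon gives a 1.1-fold higher number from compound 3 to compound 4 (0.03 log units; within the scatter), whereas the same change on the other core gives a 3.0-fold lower number from compound 2 to compound 1 (0.48 log units; beyond the scatter). The step seen on the core of compound 2 therefore does not carry over to the core of compound 3: the change is beyond the scatter on one core and within it on the other, which shows that a step read on one of these cores cannot simply be transferred to the other, but gives no general rule from just these two pairs. Nothing available here accounts for the difference between the two cores.

The compounds shown leave open whether other groups at this place, such as morpholin-4-yl, a dimethylamino group or a carboxylic acid, would behave alike on both cores. They also leave open which of the two outcomes the 4-methylpiperazin-1-yl change would follow on any further core in the series.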